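Methoxy for Trifluoromethyl on the Anilino Ring

The compounds below may be only part of what the source reports. "The series", "measured", "known", "first", "only" and "open" are said of these compounds alone.

Compound 3 `O=C(/C=C\Nc1ccc(C(F)(F)F)cc1)c1cn(-c2ccccc2)nc1-c1ccc(Cl)cc1` is tested in a functional assay on A549 cells (Homo sapiens) for antiproliferative activity, read by MTT assay, with a stated time of 48 h (a higher number here means a weaker inhibitor, a lower number a stronger inhibitor), where compound 3 gives only the assay limit > 50000 nM. Among the compounds with values here, compound 2 `O=C(/C=C\Nc1ccc(Cl)cc1)c1cn(-c2ccccc2)nc1-c1ccc(Cl)cc1` gives 3670 nM in this assay, and the change an at least 13-fold higher number from compound 2 to compound 3 (1.13 log units; beyond the scatter) is the one measured step at the same position. Compound 1 `COc1ccc(N/C=C\C(=O)c2cn(-c3ccccc3)nc2-c2ccccc2)cc1` gives 3250 nM. Compound 4 `COc1ccc(N/C=C\C(=O)c2cn(-c3ccccc3)nc2-c2ccc(Cl)cc2)cc1` differs from compound 3 by methoxy in place of trifluoromethyl on an aromatic carbon. It thereby carries the methoxy of compound 1 on the core of compound 2, and those two compounds show values within the scatter of each other. The step of an at least 14-fold lower number from compound 3 to compound 4 (1.15 log units; beyond the scatter) is therefore expected to be a large fall from the limit back into that neighbourhood. Compound 4 is estimated at 3500 nM, in the range 1500 nM to 10000 nM.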

Compound 4, half-maximal inhibitory concentration: 6460 nM
The estimate for compound 4 lay 1.8-fold (0.27 log units) below the measured number, within the range that was stated.
By their numbers in this assay, from the lowest: compounds 1, 2 and 4 (each within the scatter of the next). At a limit, above all of these: compound 3.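

Methoxy in place of trifluoromethyl gives an at least 7.7-fold lower number from compound 3 to compound 4 (0.88 log units; beyond the scatter) in this assay, so the loss seen at this position does not follow every replacement of chloro. Methoxy and chloro here cannot be told apart, with a 1.8-fold higher number from compound 2 to compound 4 (0.25 log units; within the scatter), and chloro in place of hydrogen on the shared core gives a 2.0-fold higher number from compound 1 to compound 4 (0.30 log units; within the scatter). Compound 3 stands at a limit of the assay, so its step to the methoxy compound is a bound only: the limit of > 50000 nM in this assay, at which 1 of the 4 values shown sits.

The compounds shown leave open how a nitrile, an amine or a carboxylic acid would read at this position. As far as these compounds go, whether trifluoromethyl gives the same loss on the core of compound 1 also stays open.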